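Notes on the step from compound 2 to compound 3

The compounds below may be only part of what the source reports. "The series", "measured", "known", "first", "only" and "open" are said of these compounds alone.

Values so far in a functional assay on L5178Y cells (Mus musculus) for inhibition, read by MTT assay, with a stated time of 24 h (on this read-out lower numbers stand for stronger inhibition and higher numbers for weaker inhibition), for the two measured compounds
- compound 1 `N/N=C1\C[C@@H](c2ccc(O)cc2)Oc2cc(O)cc(O)c21` gives >= 11300 nM as a limit
- compound 2 `COc1cccc(/C=N/N=C2\C[C@@H](c3ccc(O)cc3)Oc3cc(OC)cc(O)c32)c1` gives >= 11300 nM as a limit

Compound 2 stands at >= 11300 nM in this assay and this is a limit, not a number. Within the data shown here, the series so far sits at the limit of >= 11300 nM in this assay, at which 2 of the 2 values shown sit, and offers no measured step. Compound 3 `COc1cc(O)c2c(c1)O[C@H](c1ccc(O)cc1)C/C2=N\N` is still unmeasured. Its change from compound 2 is one nitrogen atom in place of a group of 10 heavy atoms (8 carbon, 1 nitrogen, 1 oxygen; one six-membered aromatic ring of carbon only), on a double-bonded nitrogen and it leaves an amino group on the double-bonded nitrogen. Compound 1 carries the same amino group and shows >= 11300 nM as its limit, so no step beyond the scatter is expected in this assay for this change. The estimated step runs a step that the limit leaves unreadable from compound 2 to compound 3 and another limit is the likeliest report. For compound 3 the expected value is 13000 nM within an estimated range of 6000 nM to 30000 nM for now.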

Compound 3, half-maximal inhibitory concentration: >= 11300 nM
Compound 3 ended at the assay's limit (the forecaster's own chance of this, stated with the estimate: 65%); the middle value lies beyond the limit too.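

In this assay compound 3 gives >= 11300 nM, a limit and not a number. The steps to compound 3 from compound 1 and compound 2 cannot be read. The compounds shown leave open whether any change on the shared core alters inhibition, with all values at one limit: the limit of >= 11300 nM in this assay, at which 3 of the 3 values shown sit.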